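A Second Chloro Group on Compound 2

This account rests on a few compounds, and the source may have more. Where it says the series, first, only, none or still open, it means among the compounds named here.

In a functional assay on MCF7 cells (Homo sapiens) for antiproliferative activity, read by MTT assay, with a stated time of 48 h (a lower number here means a stronger inhibitor, a higher number a weaker inhibitor), compound 2 (`Fc1ccc(-c2nn(-c3ccccc3)cc2-c2nc3cc(Cl)ccc3[nH]2)cc1`) gives 2230 nM and so lies below compound 1 (`Clc1cc2nc(-c3cn(-c4ccccc4)nc3-c3ccccc3)[nH]c2cc1Cl`) at 7560 nM by more than the scatter, while it cannot be told apart from compound 3 (`Cc1ccc2[nH]c(-c3cn(-c4ccccc4)nc3-c3ccc(F)cc3)nc2c1`) at 1120 nM in the same measurement. The unmeasured compound 4 (`Fc1ccc(-c2nn(-c3ccccc3)cc2-c2nc3cc(Cl)c(Cl)cc3[nH]2)cc1`) is compound 2 with chloro in place of hydrogen on an aromatic carbon and the new group sits ortho to a chloro group.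

Among the measured compounds shown here, no measured step adds a chloro group. The closest evidence is a 2.0-fold lower number from compound 2 to compound 3 (0.30 log units; within the scatter) for methyl in place of chloro on an aromatic carbon, which leaves exchange at the existing chloro without a clear effect. Both chloro groups of compound 4 also occur in compound 1 at 7560 nM but that compound has no fluoro group, so its value does not isolate the added chloro. Given compound 1 at 7560 nM a small rise in this assay is expected, and no step beyond the scatter. The expected change is a 1.3-fold higher number from compound 2 to compound 4 (0.13 log units; within the scatter) in the direction of a weaker inhibitor. For compound 4 the estimated value is 3000 nM (expected range 1100 nM to 8000 nM).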

Compound 4, half-maximal inhibitory concentration: 6930 nM
Beside the measured number, compound 4's estimate is 2.3-fold (0.36 log units) below it; measured number inside the range.
By their numbers in this assay, from the lowest: compounds 3 and 2 (each within the scatter of the next); then compounds 4 and 1 (each within the scatter of the next).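

In this assay, among the compounds shown here, the added chloro group gives the first step at this part of the molecule that lies beyond the scatter (a 3.1-fold higher number from compound 2 to compound 4 (0.49 log units; beyond the scatter)), in the direction of a weaker inhibitor. The change is modest, but it shows that this aromatic carbon, ortho to a chloro group, responds to substitution in a way that the exchange at the existing chloro group could not show. Once both chloro groups are present, the fluoro group makes no difference that can be told apart (a 1.1-fold lower number from compound 1 to compound 4 (0.04 log units; within the scatter)), so compound 4 and compound 1 stand together at the weaker end of the series, and nothing available explains why the second chloro group has this effect.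

The compounds shown leave open whether a different group on this carbon, such as an amine, a methoxy group or a carboxylic acid, would give a similar step or one in the opposite direction. They also leave open whether the added chloro group would give the same step alongside the methyl group of compound 3 rather than the chloro group of compound 2.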